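Chloro and carboxylic acid shift in an allosteric series

The source may report more compounds than this note shows. Statements on the series, on what has been measured and on what is new or still open speak of the compounds shown alone.

Compound 1 `Cc1c(OCCCCOc2ccc(C(=O)O)cc2)ccc(C(=O)CC(C)C)c1O` — 88%
Compound 2 `COC(=O)c1ccc(OCCCCOc2ccc(C(=O)CC(C)C)c(O)c2C)cc1` — 16.4%
Compound 3 `Cc1c(OCCCCOc2ccc(C(=O)O)cc2Cl)ccc(C(=O)CC(C)C)c1O` — 99.5%

In an assay on HEK293 cells for positive allosteric modulation of metabotropic glutamate receptor 2 (Rattus norvegicus), read by thallium flux, with a stated time of 2.5 min (on this read-out higher numbers stand for larger maximal responses and lower numbers for smaller maximal responses), compound 3 gives the highest of the three numbers. Its nearest neighbour is compound 1, reached by a number 11.5 percentage points higher from compound 1 to compound 3 (beyond the scatter); the furthest is compound 2, reached by a number 83.1 percentage points higher from compound 2 to compound 3 (beyond the scatter). Among the measured compounds shown here, the only large step among the measured compounds is the one in which the carboxylic acid is capped, a number 71.6 percentage points lower from compound 1 to compound 2 (beyond the scatter).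

Compound 4 `Cc1ccc(C(=O)O)cc1OCCCCOc1ccc(C(=O)CC(C)C)c(O)c1C` differs from compound 3 by 5-carboxy-2-methylphenyl in place of 4-carboxy-2-chlorophenyl on an oxygen on a saturated carbon. Both measured steps bear on this change: the acid is kept, so the large fall seen from compound 1 to compound 2 is not expected to recur, while the chloro that brought the modest gain from compound 1 to compound 3 is lost. A modest fall, a number 14.5 percentage points lower from compound 3 to compound 4 (beyond the scatter), is therefore expected, though the carboxylic acid on the new aryl group stands elsewhere than in compound 1, which adds uncertainty. Compound 4 is estimated at 85%, within 65% to 100%.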

Compound 4, largest response reached (reported as percent of maximum), in percent of the reference or control that the assay uses: 76.9%
Compound 4: middle estimate off by 8.1 percentage points, on the high side, within the range that was stated.
By their numbers in this assay, from the lowest: compound 2; then compound 4; then compound 1; then compound 3.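

In this assay, the 5-carboxy-2-methylphenyl group on the oxygen on a saturated carbon retains most of the response seen with the acid-bearing compounds, and the large step of a number 60.5 percentage points higher from compound 2 to compound 4 (beyond the scatter) keeps it well clear of the methyl ester. The exchange is not free, however: the change of aryl group gives a number 22.6 percentage points lower from compound 3 to compound 4 (beyond the scatter), and a smaller but still modest loss appears as a number 11.1 percentage points lower from compound 1 to compound 4 (beyond the scatter). This place therefore accepts a carboxyphenyl group of a different substitution pattern at a modest cost, and among these compounds neither replacement of 4-carboxyphenyl exceeds a modest step.

Among the compounds shown here, the single exchange in compound 4 does not separate the contribution of the methyl from that of the moved carboxy group, and how a tetrazole or an amide would read out in place of the carboxylic acid remains open. No measurement shown here accounts for these differences.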